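A few compounds are considered here, and "the series" means these few. Any claim that something is new, unique, unknown or untested is made for them only; others in the source may bear on it.

Measured so far:
compound 1, `CC(C)CCCN(C(=O)[C@@H]1C[C@H]1c1ccccc1)c1ccc(-c2ccccc2)cc1` — > 100 nM
compound 2, `CC[C@H](C)[C@H](N)CN(C(=O)[C@@H]1C[C@H]1c1ccc(C#N)cc1)c1ccc(-c2ccccc2)cc1` — > 25000 nM

In a functional assay for agonist activity at G protein-coupled receptor 88 (Homo sapiens), read by HTRF and cAMP accumulation (on this read-out higher numbers stand for an effect only at larger amounts of compound and lower numbers for an effect already at smaller amounts), compound 1 gives only a limit, > 100 nM. Compound 2 likewise gives only a limit, > 25000 nM, which is the limit of > 25000 nM in this assay, at which 1 of the 2 values shown sits. Going by the values given here, no step between two measured compounds is available, so no direction can be read from this pair. Compound 3, `CC[C@H](C)[C@H](N)CN(C(=O)[C@@H]1C[C@H]1c1nccs1)c1ccc(-c2ccccc2)cc1`, differs from compound 2 by 1,3-thiazol-2-yl in place of 4-cyanophenyl on a saturated ring carbon. Among the compounds with values here, with no measured step to lean on, the expected shift is small, none beyond the scatter; the estimated step is an at least 1.2-fold lower number from compound 2 to compound 3 (0.09 log units; that floor lies within the scatter). Compound 3 is expected near 20000 nM, within 3000 nM to 60000 nM, most likely again reported as a limit.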

Compound 3, half-maximal effective concentration: 210 nM
The estimate for compound 3 lay 95-fold (1.98 log units) above the measured number, and the stated range ends above it.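

The change to 1,3-thiazol-2-yl in place of 4-cyanophenyl on a saturated ring carbon gives, in this assay, an at least 110-fold lower number from compound 2 to compound 3 (2.07 log units; beyond the scatter), so this position is not indifferent to the group it carries. The value of compound 2 is a limit, so the full size of the step stays unknown: the limit of > 25000 nM in this assay, at which 1 of the 3 values shown sits.

Going by these compounds, whether the step follows from the five-membered ring, its sulfur or the loss of the nitrile stays open; a thiophen-2-yl or a pyridin-2-yl at this place would separate these. On these data alone, compound 1 differs from compound 3 in more than one place, so the role of the amine in the chain also stays open.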